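Swapping Fluoro for Nitro on a Shared Core

A few compounds are considered here, and "the series" means these few. Any claim that something is new, unique, unknown or untested is made for them only; others in the source may bear on it.

Measured compounds:
compound 1, `O=C(/C=C/c1ccc(O)c(O)c1)N1CCN(c2ccc(F)cc2)CC1`, 1.68 ug/mL
compound 2, `O=C(/C=C/c1ccc(O)c(O)c1)N1CCN(c2ccccc2Cl)CC1`, 1.82 ug/mL
compound 3, `COc1ccc(N2CCN(C(=O)/C=C/c3ccc(O)c(O)c3)CC2)cc1`, 1.21 ug/mL

These three compounds share one core and differ only in the group on the amine nitrogen in a ring. In a functional assay on B16-F10 cells (Mus musculus) for antiproliferative activity, read by MTT assay, with a stated time of 48 h (a lower number here means a stronger inhibitor, a higher number a weaker inhibitor), compound 1 gives 1.68 ug/mL, and its two neighbours fall close by: one step is a 1.1-fold higher number from compound 1 to compound 2 (0.03 log units; within the scatter), the other 1.4-fold lower number from compound 1 to compound 3 (0.14 log units; within the scatter). The remaining pair also stays close, with a 1.5-fold lower number from compound 2 to compound 3 (0.18 log units; within the scatter). So compound 1 stands among numbers that cannot be told apart.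

Going by these compounds, compound 4, `O=C(/C=C/c1ccc(O)c(O)c1)N1CCN(c2ccc([N+](=O)[O-])cc2)CC1`, is still untested. Against compound 1 the change is nitro in place of fluoro on an aromatic carbon. Among the measured compounds shown here, the step that bears on it most is the one from compound 1 to compound 3, which also replaces the fluoro on the same aromatic carbon and stays within the scatter; the other two steps are within the scatter as well. No step beyond the scatter is therefore expected in this assay . Compound 4 is estimated at 1.6 ug/mL, within 0.75 ug/mL to 3.4 ug/mL, which means an expected step of a 1.1-fold lower number from compound 1 to compound 4 (0.02 log units; within the scatter).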

Compound 4, half-maximal inhibitory concentration: 1.79 ug/mL
Compound 4: the middle estimate sits 1.1-fold (0.05 log units) below what was measured; measured number inside the range.
By their numbers in this assay, from the lowest: compounds 3, 1, 4 and 2 (each within the scatter of the next).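

In this assay the 4-nitrophenyl group gives a 1.1-fold higher number from compound 1 to compound 4 (0.03 log units; within the scatter) and, against the other two compounds, a 1.5-fold higher number from compound 3 to compound 4 (0.17 log units; within the scatter) and a 1.0-fold lower number from compound 2 to compound 4 (0.01 log units; within the scatter). Nitro brings 3 heavy atoms and 2 hydrogen-bond acceptors onto this aromatic carbon, where fluoro has 1 heavy atom and 0 hydrogen-bond acceptors, yet all four numbers on the shared core still cannot be told apart, so this larger change is the first to show that even such a swap at this position gives no readable step. No measurement here explains why the numbers stay together.

The compounds shown leave open whether any group at this position can move the number beyond the scatter. An amine, a carboxylic acid or a longer chain on the same aromatic carbon would put that question to a different kind of group.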